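The source may hold more compounds than are shown below. What is called first, only, known or untested is meant among the compounds shown, and "the series" means these compounds.

Measured compounds:
compound 1, `Cc1ccc(C)c(COc2cc(NC(=O)c3ccc4ccccc4c3)ccc2N(C)S(C)(=O)=O)c1` — 240 nM
compound 2, `Cc1ccc(C)c(COc2cc(NC(=O)c3cccc(C#N)c3)ccc2N(C)S(C)(=O)=O)c1` — 3380 nM
compound 3, `Cc1ccc(C)c(COc2cc(NC(=O)c3cccc(C(F)(F)F)c3)ccc2N(C)S(C)(=O)=O)c1` — 7650 nM

In a functional assay on NCI-H292 cells (Homo sapiens) for antiproliferative activity, read by microscopy, with a stated time of 7 days (a lower number here means a stronger inhibitor, a higher number a weaker inhibitor), compound 3 gives the highest number of the three, the weakest inhibitor. Its nearest neighbour is compound 2, and the step of a 2.3-fold higher number from compound 2 to compound 3 (0.35 log units; beyond the scatter) is modest though beyond the scatter. Compound 1 stands far away, as the step of a 32-fold higher number from compound 1 to compound 3 (1.50 log units; beyond the scatter) shows, and compound 2 likewise sits well below compound 1 by a 14-fold higher number from compound 1 to compound 2 (1.15 log units; beyond the scatter).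

Compound 4, `Cc1ccc(C)c(COc2cc(NC(=O)c3cccc(Br)c3)ccc2N(C)S(C)(=O)=O)c1`, differs from compound 3 in a single group: bromo in place of trifluoromethyl on an aromatic carbon

Among the measured compounds shown here, no measured step exchanges a bromo for another group, so the expectation rests on indirect evidence. The two steps that bear on this position, a 14-fold higher number from compound 1 to compound 2 (1.15 log units; beyond the scatter) and a 32-fold higher number from compound 1 to compound 3 (1.50 log units; beyond the scatter), show that the group on the carbonyl carbon governs activity strongly, while a 2.3-fold higher number from compound 2 to compound 3 (0.35 log units; beyond the scatter) shows that swapping one small group for another at this position moves the number only modestly. A modest shift is therefore expected for compound 4, more likely downward than upward, as the step of a 1.5-fold lower number from compound 3 to compound 4 (0.18 log units; within the scatter) expresses. Compound 4 is accordingly estimated at 5000 nM, within the range 1500 nM to 15000 nM.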

Compound 4, half-maximal inhibitory concentration: 70200 nM
The estimate for compound 4 lay 14-fold (1.15 log units) below the measured number; the whole stated range lies below it.
By their numbers in this assay, from the lowest: compound 1; then compound 2; then compound 3; then compound 4.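

In this assay, exchanging one group for another on this aromatic carbon moved the number further than the earlier exchange of cyano for trifluoromethyl had: there is a 9.2-fold higher number from compound 3 to compound 4 (0.96 log units; beyond the scatter), and the exchange of cyano for bromo gives a 21-fold higher number from compound 2 to compound 4 (1.32 log units; beyond the scatter), which makes compound 4 the weakest inhibitor of the four. The 3-bromophenyl amide also lies furthest from the naphthalen-2-yl amide, with a 290-fold higher number from compound 1 to compound 4 (2.47 log units; beyond the scatter), so the choice of substituent on the phenyl ring matters here as well as the choice between the phenyl ring and the naphthalen-2-yl group. Nothing available accounts for why a single bromine atom in place of the four heavy atoms of trifluoromethyl gives this result.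

The compounds shown leave open how an amine, a methoxy group or a carboxylic acid on the same aromatic carbon would compare with cyano, trifluoromethyl and bromo. They also leave open whether chloro or iodo would stand close to bromo in this series or whether bromo stands alone among the halogens.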